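Ring size on the compound 2 side chain

The source may hold more compounds than are shown below. What is called first, only, known or untested is meant among the compounds shown, and "the series" means these compounds.

Measured in a physicochemical assay for solubility, read by chemiluminescence, measured as kinetic solubility; a lower number here means a less soluble compound, a higher number a more soluble compound:
- compound 1 `O=C([C@H]1CCCCN1)N1CCC2(CCN(c3nccc(NCc4ccc(Cl)cc4Cl)n3)CC2)C1`: 172 ug/mL
- compound 2 `Clc1ccc(CNc2ccnc(N3CCC4(CCN(C[C@H]5CCCN5)C4)CC3)n2)c(Cl)c1`: 16 ug/mL

Compound 2 holds the lower of the two numbers, and the step of an 11-fold lower number from compound 1 to compound 2 (1.03 log units; beyond the scatter) lies beyond the scatter. Compound 3 `Clc1ccc(CNc2ccnc(N3CCC4(CCN(CC5CCCCN5)C4)CC3)n2)c(Cl)c1` is unmeasured and carries piperidin-2-yl in place of pyrrolidin-2-yl on a saturated chain carbon bound to an amine nitrogen in a ring. Among the compounds with values here, the only measured step, an 11-fold lower number from compound 1 to compound 2 (1.03 log units; beyond the scatter), bears on this partly, since it replaced (piperidin-2-yl)carbonyl with (pyrrolidin-2-yl)methyl. Within the data shown here, no measured step isolates the ring change, so no shift beyond the scatter is expected in this assay. The expected step is a 1.1-fold higher number from compound 2 to compound 3 (0.05 log units; within the scatter). Compound 3 is estimated at 18 ug/mL, with an expected range of 7 ug/mL to 45 ug/mL.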

Compound 3, solubility: 182 ug/mL
The estimate for compound 3 lay 10-fold (1.00 log units) below the measured number, outside the stated range (above it).
By their numbers in this assay, from the lowest: compound 2; then compounds 1 and 3 (each within the scatter of the next).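

In this assay, this position responds strongly to ring size: piperidin-2-yl in place of pyrrolidin-2-yl gives an 11-fold higher number from compound 2 to compound 3 (1.06 log units; beyond the scatter). With piperidin-2-yl held constant, (piperidin-2-yl)methyl in place of (piperidin-2-yl)carbonyl gives a 1.1-fold higher number from compound 1 to compound 3 (0.02 log units; within the scatter), so the carbonyl-to-methylene change alone does not reproduce the large step seen with compound 2. No measurement available here explains the ring effect. Compound 2 has a defined stereocentre in this group and compound 3 has none, so ring size and stereochemistry remain unseparated. From the compounds shown here alone, whether azepan-2-yl or morpholin-3-yl would track compound 2 or compound 3 remains open.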